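The compounds below may be only part of what the source reports. "The series", "measured", "known", "first", "only" and "open" are said of these compounds alone.

Compound 1 `CC(=O)Oc1ccccc1C(=O)OCC[Se]C#N` is an ester of a salicylate core carrying a selenocyanate-terminated chain. In a functional assay on HT-29 cells (Homo sapiens) for antiproliferative activity, read by MTT assay, with a stated time of 48 h (a higher number here means a weaker inhibitor, a lower number a stronger inhibitor), compound 1 gives 30900 nM, the higher of the two numbers obtained in this series. Compound 2 `CC(=O)Oc1ccccc1C(=O)[Se]CC[Se]C(=O)c1ccccc1OC(C)=O`, a diselenoester, gives 3500 nM in this assay, and the gap to compound 1 lies beyond the scatter. For compound 3 `C[Se]CC(NC(=O)c1ccccc1OC(C)=O)C(=O)O` this assay reports only a limit, > 50000 nM (the limit of > 50000 nM in this assay, at which 1 of the 3 values shown sits), and no number.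

Compound 4 `CC(=O)Oc1ccccc1C(=O)NCCSC#N` differs from compound 1 by a group of 6 heavy atoms (3 carbon, 2 nitrogen, 1 sulfur; no ring) in place of a group of 6 heavy atoms (3 carbon, 1 nitrogen, 1 oxygen, 1 selenium; no ring), on a carbonyl carbon; in words, a group of six heavy atoms, containing sulfur and an amide nitrogen, replaces the selenium-containing ester chain on the carbonyl carbon. Among the measured compounds shown here, no measured pair covers this change. Compound 4 is expected to give 45000 nM in this assay, within 15000 nM to 150000 nM, an expected step of a 1.5-fold higher number from compound 1 to compound 4 (0.16 log units; within the scatter) towards weaker inhibition, with a real chance that only a limit is returned.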

Compound 4, half-maximal inhibitory concentration: > 50000 nM
Compound 4 ended at the assay's limit (the forecaster's own chance of this, stated with the estimate: 45%); middle value at least 1.1-fold (0.04 log units) away from the limit.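

In this assay, the change on the carbonyl carbon gives an at least 1.6-fold higher number from compound 1 to compound 4 (0.20 log units; that floor lies within the scatter), so the (2-(cyanosulfanyl)ethyl)amino group shows no gain over the selenium-containing chain of compound 1. This single step exchanges both the ester oxygen for an amide nitrogen and selenium for sulfur, so it cannot be assigned to either exchange alone. Compound 4 returns only a limit, and the series now stands as follows: the limit of > 50000 nM in this assay, at which 2 of the 4 values shown sit.

As far as these compounds go, whether an ester with the sulfur chain or an amide with the selenium chain would match compound 1 remains open. From the compounds shown here alone, the effect of a longer chain or a terminal amine at this place also remains open.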